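Azido in place of methylsulfanyl on the shared core

The source may hold more compounds than are shown below. What is called first, only, known or untested is meant among the compounds shown, and "the series" means these compounds.

Compound 1 `CSc1[nH]ccc2ncnc1-2`: 4%
Compound 2 `OC[C@H]1O[C@@H](n2cnc3c(NCc4ccccc4)nccc32)C[C@@H]1O`: 15%
Compound 3 `OC[C@H]1O[C@@H](n2cnc3cnccc32)[C@H](O)[C@@H]1O`: 13%; 1% (2 entries)

In a functional assay (Homo sapiens) for inhibition of Nucleic Acid, tested at 100 uM (on this read-out higher numbers stand for more inhibition at the one concentration tested (going by the name of the read-out) and lower numbers for less inhibition), compound 1 gives the lower of the two single numbers; compound 2 sits higher by a margin beyond the scatter, while compound 3 has several entries, (the several entries of compound 3 in this assay, 13%; 1% (2 entries)), that spread across the scatter and yield no single number. Compound 4 `[N-]=[N+]=Nc1[nH]ccc2ncnc1-2` differs from compound 1 by azido in place of methylsulfanyl on an aromatic carbon. Among the measured compounds shown here, no step between two measured compounds is recorded, and no comparable change has been measured, so the change can only be judged from the low values seen so far. The step expected is a number 2 percentage points higher from compound 1 to compound 4 (within the scatter), no larger than the scatter in either direction. Compound 4 is estimated at 6%, within a range from 0% to 20%.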

Compound 4, a percentage reported as inhibition, at one concentration (the size of the read-out at that concentration, not a potency): 20%
Compound 4: middle estimate off by 14 percentage points, on the low side; the range from low to high includes it.
By their numbers in this assay, from the lowest: compound 1; then compounds 2 and 4 (each within the scatter of the next).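

Azido in place of methylsulfanyl on an aromatic carbon, next to the ring nitrogen, is the only single change recorded on the shared core, and in this assay it reads as a number 16 percentage points higher from compound 1 to compound 4 (beyond the scatter) on one concentration. This position therefore responds to the group placed on it, though the step remains modest. Nothing shown bears on why this step arises.

Open: whether an amine or a chlorine atom on the same aromatic carbon would shift the read-out further, and whether a longer chain there would keep the step.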